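The source may report more compounds than this note shows. Statements on the series, on what has been measured and on what is new or still open speak of the compounds shown alone.

Working notes on the series. Compound 1 `CCC(CC)(CC(=O)Nc1cccc(OCc2ccc3c(F)cccc3n2)c1)C(=O)O` gives 0.3 nM in a functional assay on ileum (Cavia porcellus) for antagonist activity at cysteinyl leukotriene receptor (Homo sapiens); a lower number here means a stronger inhibitor, a higher number a weaker inhibitor. Compound 2 `CCC(CC)(CC(=O)Nc1cccc(OCc2ccc3cc(F)c(F)cc3n2)c1)C(=O)O` gives 0.5 nM in this assay. Compound 3 `CCC(CC)(CC(=O)Nc1cccc(OCc2ccc3ccc(Br)cc3n2)c1)C(=O)O` gives 4 nM in this assay, the highest of the three numbers: the gap to compound 2 lies beyond the scatter, and the gap to compound 1 is wider still. For the measured compounds named here, no two measured compounds differ in a single place, so no single structural change in this set has a measured size attached to it, and the bromo group of compound 3 cannot be weighed on its own against the fluoro groups of compound 1 and compound 2.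

Compound 4 `CCC(CC)(CC(=O)Nc1cccc(OCc2ccc3ccc(C)cc3n2)c1)C(=O)O` is the next compound, not yet measured in this assay. It differs from compound 3 in one place: methyl in place of bromo on an aromatic carbon. Bromo and methyl are each a single heavy atom with no donor, acceptor or charge, so the change is small on paper. Going by the values given here, with no measured step of this kind to lean on, the expectation in this assay is a step of modest size at most, if anything toward a lower number, and possibly none beyond the scatter. Because compound 3 gives 4 nM, the estimate for compound 4 is 2.5 nM, with a range from 0.6 nM to 10 nM. That estimate means an expected step of a 1.6-fold lower number from compound 3 to compound 4 (0.20 log units; within the scatter).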

Compound 4, half-maximal inhibitory concentration: 11 nM
For compound 4 the middle estimate is 4.4-fold (0.64 log units) below the measured one; the measured number lies above the stated range.
By their numbers in this assay, from the lowest: compounds 1 and 2 (each within the scatter of the next); then compound 3; then compound 4.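

For the compounds shown here, the step of a 2.8-fold higher number from compound 3 to compound 4 (0.44 log units; beyond the scatter) in this assay is the first measured single change: methyl in place of bromo on an aromatic carbon, meta to a fused ring and para to a fused ring. It shows that this carbon is not indifferent to the group it carries, even though bromo and methyl match in what can be counted here: each has one heavy atom, with no hydrogen-bond donors, no hydrogen-bond acceptors and no net charge. The step is modest but lies beyond the scatter, with bromo on the side of the lower number, and no measurement at hand bears on what lies behind it.

A single pair cannot show whether the order of bromo and methyl reflects a wider trend at this carbon, and chloro, methoxy, trifluoromethyl or a plain hydrogen there would place it on a broader scale. Also open, going by these compounds, is whether the same replacement gives a step of similar size and direction on a core that carries other groups on the same ring.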